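This account rests on a few compounds, and the source may have more. Where it says the series, first, only, none or still open, it means among the compounds named here.

Compound 1 `Cc1ccc(S(=O)(=O)Nc2ccc(-c3nc4ccccc4o3)cc2)cc1`: in an assay on isolated protein for inhibition of malate dehydrogenase, mitochondrial (Sus scrofa), with stated times of 45 min and 30 min (on this read-out lower numbers stand for stronger inhibition and higher numbers for weaker inhibition), compound 1 gives > 63000 nM, which is a limit of the assay and not a number.
Compound 2 `O=S(=O)(Nc1ccc(-c2nc3ccccc3o2)cc1)c1ccccc1Cl`: in this assay compound 2 gives > 63000 nM, again only a limit.
Compound 3 `O=S(=O)(Nc1ccc(-c2nc3ccccc3o2)cc1)c1cccc(Cl)c1`: in this assay compound 3 gives > 63000 nM, also a limit.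

Compound 3 thus stands where every measured compound here stands, at the limit of > 63000 nM in this assay, at which 3 of the 3 values shown sit, with no number that would set it apart from the others. Compound 4 `O=S(=O)(Nc1ccc(-c2nc3ccccc3o2)cc1)c1ccccc1F` differs from it by 2-fluorophenyl in place of 3-chlorophenyl on a sulfonyl sulfur. The measured steps that bear on this change, a step that the two limits leave unreadable from compound 1 to compound 2, a step that the two limits leave unreadable from compound 1 to compound 3 and a step that the two limits leave unreadable from compound 2 to compound 3, each join two limits, so their size cannot be read and no direction can be taken from them. Compound 4 is expected to remain at the limit, so the expected step that the limit leaves unreadable from compound 3 to compound 4 carries no real information. The estimate for compound 4 is 100000 nM, with a range from 30000 nM to 400000 nM.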

Compound 4, half-maximal inhibitory concentration: > 63000 nM
Compound 4 ended at the assay's limit; the forecaster's own chance of this, stated with the estimate: 85%; the middle value lies beyond the limit too.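

Compound 4 sits at a limit, as do compound 1, compound 2 and compound 3, so no step among them can be read: the limit of > 63000 nM in this assay, at which 4 of the 4 values shown sit.

Going by these compounds, none of the four gives a number in this assay, so whether changing the group on the sulfonyl sulfur alters inhibition stays open.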